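Hydroxy to 4-Hydroxyphenyl on the Shared Core

The source may hold more compounds than are shown below. What is called first, only, known or untested is meant among the compounds shown, and "the series" means these compounds.

Compound 1, `O=c1cc(/C=N\O)c2c(OCc3ccccc3)cc(OCc3ccccc3)cc2o1`, gives "not active" (no number reported) in a functional assay, read by spectrophotometry, with a stated time of 1 h; a lower number here means a stronger inhibitor, a higher number a weaker inhibitor.
Compound 2, `O=c1cc(/C=N\O)c2ccc(OCc3ccccc3)cc2o1`, gives > 2000000 nM in this assay, and that value is a limit of the assay, not a number.

Going by the values given here, compound 1 therefore has no single number in this assay, and the only other value shown is the limit of > 2000000 nM in this assay, at which 1 of the 2 values shown sits. Compound 3, `O=c1cc(/C=N\c2ccc(O)cc2)c2c(OCc3ccccc3)cc(OCc3ccccc3)cc2o1`, has not been measured. It differs from compound 1 in one place: 4-hydroxyphenyl in place of hydroxy on a double-bonded nitrogen. Among the compounds with values here, no measured step between related compounds is available, so the effect of this change is unknown; with both measured compounds showing no measurable inhibition, no step beyond the usual scatter is expected in either direction. Compound 3 is estimated at 1500000 nM, within a range of 200000 nM to 5000000 nM.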

Compound 3, half-maximal inhibitory concentration: 107000 nM
Compound 3: the middle estimate sits 14-fold (1.15 log units) above what was measured; measured number below the stated range.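

No step can be read from compound 1 to compound 3: in this assay compound 1 gives "not active" (no number reported), which leaves no number to set against compound 3. The compounds shown leave open how much the 4-hydroxyphenyl group on the double-bonded nitrogen changes inhibition.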